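The source may report more compounds than this note shows. Statements on the series, on what has been measured and on what is new or still open speak of the compounds shown alone.

Of the compounds shown here, three have been tested in an ADME assay on MRC5 cells (Homo sapiens) for cytotoxicity, read by MTT assay, with a stated time of 72 h; on this read-out lower numbers stand for higher toxicity in this test and higher numbers for lower toxicity in this test. Compound 1 `OC[C@H]1O[C@@H](n2cc(F)c3c(-c4ccco4)ncnc32)[C@H](O)[C@@H]1O` gives 29000 nM, and compound 2 `OC[C@H]1O[C@@H](n2cc(F)c3c(-c4ccc[nH]4)ncnc32)[C@H](O)[C@@H]1O` gives 44500 nM. Compound 3 `CCCCCCCCCCCCCCCCCCOP(=O)(O)OC[C@H]1O[C@@H](n2ccc3c(-c4ccoc4)ncnc32)[C@H](O)[C@@H]1O` gives > 50000 nM, which is a limit and not a number. This reading is the limit of > 50000 nM in this assay, at which 1 of the 3 values shown sits, so compound 3 has no exact place on the scale.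

Compound 4 `CCCCCCCCCCCCCCCCCCOP(=O)(O)OC[C@H]1O[C@@H](n2ccc3c(-c4ccsc4)ncnc32)[C@H](O)[C@@H]1O` differs from compound 3 in one place: thiophen-3-yl in place of furan-3-yl on an aromatic carbon. Within the data shown here, no measured step covers this exchange directly. The nearest is the exchange of one five-membered aromatic ring for another on a different parent, which gives a 1.5-fold higher number from compound 1 to compound 2 (0.19 log units; within the scatter). Among the measured compounds shown here, that single step is the only guide, and it does not exceed the scatter, so no clear shift in either direction is expected in this assay on going to the thiophen-3-yl compound. The estimated step is a number no higher from compound 3 to compound 4 (the limit leaves the size open), and it should be read against a limit rather than a number. For compound 4 the expected value is 50000 nM, within an estimated range of 25000 nM to 100000 nM.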

Compound 4, half-maximal cytotoxic concentration: > 50000 nM
Compound 4: only a limit was reported (the forecaster's own chance of this, stated with the estimate: 65%); the middle value lies on the limit itself.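

Compound 4, like compound 3, is reported only as a limit, so no step can be read for thiophen-3-yl in place of furan-3-yl: the limit of > 50000 nM in this assay, at which 2 of the 4 values shown sit.

The compounds shown leave open where compound 3 and compound 4 actually lie on the scale, and whether this exchange changes the read-out at all.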